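A few compounds are considered here, and "the series" means these few. Any claim that something is new, unique, unknown or untested is made for them only; others in the source may bear on it.

Measured in a physicochemical assay for solubility, in phosphate buffer, at pH 7.4; a lower number here means a less soluble compound, a higher number a more soluble compound:
- compound 1 `CCOC(=O)c1c(-c2ccc(OC)cc2)[nH]c2cccc(OC)c2c1=O`: > 100000 nM
- compound 2 `CCOC(=O)c1c(-c2ccccc2)[nH]c2cc(OC)ccc2c1=O`: > 100000 nM
- compound 3 `CCOC(=O)c1c(-c2ccccc2Cl)[nH]c2cc(OC)ccc2c1=O`: 28000 nM

Compound 1 gives > 100000 nM, which is a limit of the assay and not a number. The same limit recurs: the limit of > 100000 nM in this assay, at which 2 of the 3 values shown sit.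

Compound 4 `CCOC(=O)c1c(-c2ccccc2C)[nH]c2cccc(OC)c2c1=O` differs from compound 1 by a single change: 2-methylphenyl in place of 4-methoxyphenyl on an aromatic carbon. In words, 2-methylphenyl stands in place of 4-methoxyphenyl on an aromatic carbon, next to the ring nitrogen.

For the measured compounds named here, only one measured step bears on this, and it is a loose guide: an at least 3.5-fold lower number from compound 2 to compound 3 (0.55 log units; beyond the scatter), with chloro in place of hydrogen on an aromatic carbon. A step of similar size towards a lower number is therefore expected in this assay. The expected step is an at least 2.8-fold lower number from compound 1 to compound 4 (0.45 log units; beyond the scatter). For compound 4 the estimate is 35000 nM, with an expected range of 12000 nM to 100000 nM.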

Compound 4, solubility: > 100000 nM
Compound 4 ended at the assay's limit (the forecaster's own chance of this, stated with the estimate: 35%); at least 2.8-fold (0.45 log units) between middle value and limit.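

No step can be read from compound 1 to compound 4, as both end at the same limit in this assay: the limit of > 100000 nM in this assay, at which 3 of the 4 values shown sit.

On these data alone, whether 2-methylphenyl in place of 4-methoxyphenyl changes the number at all, and in which direction, stays open.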